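This account rests on a few compounds, and the source may have more. Where it says the series, first, only, none or still open, it means among the compounds named here.

Measured compounds:
compound 1 `COc1nn(Cc2ccccc2)c(=O)o1`: "not active" (no number reported)
compound 2 `COc1nn(Cc2ccccc2-c2ccccc2)c(=O)o1`: 23%

In an assay on COS-7 cells for inhibition of Fatty-acid amide hydrolase 1 (Homo sapiens), read by scintillation counting, with a stated time of 10 min, tested at 10 uM (on this read-out higher numbers stand for more inhibition at the one concentration tested (going by the name of the read-out) and lower numbers for less inhibition), compound 1 gives "not active" (no number reported), so no number stands for it. Within the data shown here, the only figure comes from compound 2, which in this assay gives 23%. Compound 3 `COc1nn(Cc2ccc([N+](=O)[O-])cc2)c(=O)o1` has not yet been tested. It differs from compound 1 in one place: nitro in place of hydrogen on an aromatic carbon. Among the measured compounds shown here, no step between measured compounds is recorded, so the size of this change is open; a small rise in this assay over compound 1 is expected, probably not beyond the usual scatter. Compound 3 is estimated to give 12%, ranging from 0% to 35%.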

Compound 3, a percentage reported as inhibition, at one concentration (the size of the read-out at that concentration, not a potency): 18%
Beside the measured number, compound 3's estimate is 6 percentage points below it, and the stated range covers the measured number.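

In this assay, among these compounds, compound 1 gives "not active" (no number reported) and so leaves no step to compound 3 that can be read. How far nitro in place of hydrogen moves inhibition stays open, and no measurement shown here bears on a cause.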